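Pyrimidin-2-yl in Place of 4-Fluorophenyl: Compound 4

The source may report more compounds than this note shows. Statements on the series, on what has been measured and on what is new or still open speak of the compounds shown alone.

Of the compounds shown here, three that share a core have been measured in a functional assay on HeLa cells (Homo sapiens) for antiproliferative activity, read by CCK-8 assay, with a stated time of 72 h, tested at 2 uM; on this read-out higher numbers stand for a stronger effect at the one concentration tested and lower numbers for a weaker effect. Compound 1 `Nc1ccccc1NC(=O)c1ccc(CSC(=S)N2CCN(C(c3ccccc3)c3ccccc3)CC2)cc1` gives 8%, compound 3 `CC1CCCCN1C(=S)SCc1ccc(C(=O)Nc2ccccc2N)cc1` gives 45.5%, and compound 2 `Nc1ccccc1NC(=O)c1ccc(CSC(=S)N2CCN(c3ccc(F)cc3)CC2)cc1` gives 60.8%. Compound 2 stands highest of the three numbers: it lies beyond the scatter above compound 3 and far beyond it above compound 1.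

Compound 4 `Nc1ccccc1NC(=O)c1ccc(CSC(=S)N2CCN(c3ncccn3)CC2)cc1` has not yet been measured. It differs from compound 2 in one place: pyrimidin-2-yl in place of 4-fluorophenyl on an amine nitrogen in a ring. Within the data shown here, no step between two measured compounds that differ in only one place is available, so the size of this particular change cannot be read off from the data; the three measured compounds differ from one another in larger ways.

In this assay the expected step of a number 15.8 percentage points lower from compound 2 to compound 4 (beyond the scatter) is small to moderate and most likely downward, not certainly beyond the scatter. Compound 4 is estimated at 45%, with an expected range from 20% to 68%.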

Compound 4, a percentage reported as inhibition, at one concentration (the size of the read-out at that concentration, not a potency): 52.2%
The estimate for compound 4 lay 7.2 percentage points below the measured number, within the range that was stated.
By their numbers in this assay, from the lowest: compound 1; then compounds 3, 4 and 2 (each within the scatter of the next, the first and the last beyond it).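

In this assay, among these compounds, the change gives the first step between two compounds that differ in one place: a number 8.6 percentage points lower from compound 2 to compound 4 (within the scatter). On this amine nitrogen in a ring, pyrimidin-2-yl, an aromatic ring with 2 hetero atoms and 2 hydrogen-bond acceptors, can therefore stand in place of 4-fluorophenyl, an aromatic ring of carbon only with 0 hydrogen-bond acceptors, without a step beyond the scatter. No measurement at hand accounts for this result.

The compounds shown leave open how a plain phenyl, a pyridin-2-yl or an acetyl group on the same amine nitrogen would read in this assay. They also leave open whether compound 2 and compound 4 would still read alike at other concentrations.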